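A Chlorine for a Fluorine on the Shared Core

The source may hold more compounds than are shown below. What is called first, only, known or untested is meant among the compounds shown, and "the series" means these compounds.

In a functional assay on HepG2 cells (Homo sapiens) for antiproliferative activity, read by MTT assay, with a stated time of 48 h (on this read-out higher numbers stand for weaker inhibition and lower numbers for stronger inhibition), compound 1 (`O=[N+]([O-])c1cc(C(F)(F)F)cc([N+](=O)[O-])c1Oc1ccccc1/C=N/OCc1ccccc1Cl`) gives 1170 nM and compound 2 (`O=[N+]([O-])c1cc(C(F)(F)F)cc([N+](=O)[O-])c1Oc1ccc(Br)cc1/C=N\OCc1ccccc1F`) gives 890 nM on the same scale. These two numbers lie within the usual scatter of each other, so compound 2 stands level with compound 1. Compound 3 (`O=[N+]([O-])c1cc(C(F)(F)F)cc([N+](=O)[O-])c1Oc1ccc(Br)cc1/C=N/OCc1ccccc1Cl`) differs from compound 2 by a group of 11 heavy atoms (8 carbon, 1 nitrogen, 1 oxygen, 1 chlorine; one six-membered aromatic ring of carbon only) in place of a group of 11 heavy atoms (8 carbon, 1 nitrogen, 1 oxygen, 1 fluorine; one six-membered aromatic ring of carbon only), on an aromatic carbon on an aromatic carbon, ortho to a large group and meta to a bromo group. For the measured compounds named here, no measured step isolates this change, so no step beyond the scatter is expected in this assay. The estimated 1.1-fold higher number from compound 2 to compound 3 (0.03 log units; within the scatter) therefore stays small. For compound 3 the expected value is 950 nM (range 400 nM to 2200 nM).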

Compound 3, half-maximal inhibitory concentration: 1240 nM
Beside the measured number, compound 3's estimate is 1.3-fold (0.12 log units) below it; the measured number falls inside the stated range.
By their numbers in this assay, from the lowest: compounds 2, 1 and 3 (each within the scatter of the next).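

In this assay, the group carrying chlorine in place of the group carrying fluorine, on an aromatic carbon ortho to a large group, gives a 1.4-fold higher number from compound 2 to compound 3 (0.14 log units; within the scatter) and bromo in place of hydrogen gives a 1.1-fold higher number from compound 1 to compound 3 (0.03 log units; within the scatter) on this read-out. Neither change therefore separates these compounds beyond the scatter. Nothing available here accounts for these results. On these data alone, whether an amine or a carboxylic acid at this position would shift the number beyond the scatter remains open, as does the outcome of a longer chain there.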